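Working notes: a sulfonyl group on compound 3

The source may hold more compounds than are shown below. What is called first, only, known or untested is meant among the compounds shown, and "the series" means these compounds.

compound 1 `COC(=O)c1ccc(C2SCC(=O)N2c2ccc(N3CCN(Cc4cccc([N+](=O)[O-])c4)CC3)cn2)c(OC)c1` gives 68700 nM
compound 2 `COC(=O)c1ccc(C2SCC(=O)N2c2ccc(N3CCN(S(=O)(=O)c4ccc(F)cc4)CC3)cn2)c(OC)c1` gives > 100000 nM as a limit of the assay
compound 3 `COC(=O)c1ccc(C2SCC(=O)N2c2ccc(N3CCNCC3)cn2)c(OC)c1` gives 15200 nM

In a functional assay on K562 cells (Homo sapiens) for antiproliferative activity, read by MTT assay and trypan blue exclusion, with a stated time of 72 h (a higher number here means a weaker inhibitor, a lower number a stronger inhibitor), compound 3 holds the lowest number of the three, at 15200 nM with a free amine nitrogen in the ring. Hydrogen in place of 3-nitrobenzyl gives a 4.5-fold lower number from compound 1 to compound 3 (0.66 log units; beyond the scatter) as the closest comparison. Hydrogen in place of (4-fluorophenyl)sulfonyl gives an at least 6.5-fold lower number from compound 2 to compound 3 (0.81 log units; beyond the scatter) as the larger measured gap.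

Compound 4 `COC(=O)c1ccc(C2SCC(=O)N2c2ccc(N3CCN(S(=O)(=O)c4ccc([N+](=O)[O-])cc4)CC3)cn2)c(OC)c1` has (4-nitrophenyl)sulfonyl in place of hydrogen on an amine nitrogen in a ring, the counted change being (4-nitrophenyl)sulfonyl in place of hydrogen on an amine nitrogen in a ring at the position where compound 2 carries its (4-fluorophenyl)sulfonyl. The closest guide is therefore compound 2, whose > 100000 nM is a limit and not a number. Both substituted compounds lie higher than compound 3, so the gap of an at least 6.5-fold lower number from compound 2 to compound 3 (0.81 log units; beyond the scatter) points to a clear rise when read in reverse. The size expected in this assay is a 4.9-fold higher number from compound 3 to compound 4 (0.69 log units; beyond the scatter) as an estimate. The expected result may also reach the limit of > 100000 nM in this assay, at which 1 of the 3 values shown sits, and return no number. For compound 4 the estimate is 75000 nM with an expected range of 30000 nM to 100000 nM in this reading.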

Compound 4, half-maximal inhibitory concentration: 65200 nM
Compound 4: the middle estimate sits 1.2-fold (0.06 log units) above what was measured; the range from low to high includes it.
By their numbers in this assay, from the lowest: compound 3; then compounds 4 and 1 (each within the scatter of the next). At a limit, above all of these: compound 2.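

In this assay, (4-nitrophenyl)sulfonyl on the amine nitrogen in the ring gives the sulfonyl series a measured number rather than a limit, and it costs activity against the free nitrogen: a 4.3-fold higher number from compound 3 to compound 4 (0.63 log units; beyond the scatter). Exchanging the sulfonyl group for the benzyl group gives a 1.1-fold lower number from compound 1 to compound 4 (0.02 log units; within the scatter), so these two substituents cannot be told apart here, and compound 3, with hydrogen at this nitrogen, keeps the lowest number of the four. Compound 2 stands at a limit and not a number, so nitro in place of fluoro on an aromatic carbon can be read only as a floor, an at least 1.5-fold lower number from compound 2 to compound 4 (0.18 log units; that floor lies within the scatter), which does not establish an effect of this exchange: the limit of > 100000 nM in this assay, at which 1 of the 4 values shown sits.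

The compounds shown leave open whether any group on this amine nitrogen can match the free nitrogen of compound 3, for example a methyl, an acetyl or a methylsulfonyl group. They also leave open whether the group on the aromatic ring of the sulfonyl substituent matters at all, which a hydrogen or an amine in place of the nitro group could test.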